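The source may report more compounds than this note shows. Statements on the series, on what has been measured and on what is new or still open speak of the compounds shown alone.

For the measured compounds named here, compound 2 `Cc1ccc(S(=O)(=O)n2cc(-c3cc(C(F)(F)F)cc(-c4cn(S(=O)(=O)c5ccc(C)cc5)c5cc(Br)ccc45)n3)c3ccc(Br)cc32)cc1` gives 8.1% in a functional assay on P388 cells (Mus musculus) for inhibition, tested at 0.1 uM (on this read-out lower numbers stand for a weaker effect and higher numbers for a stronger effect at the one concentration tested), and the only other number recorded, from compound 1 `Cc1ccc(S(=O)(=O)n2cc(-c3cc(C(F)(F)F)ccn3)c3cc(Br)ccc32)cc1`, which gives 9.7%, sits within the scatter of it, so compound 2 stands level with compound 1. Compound 3 `Cc1ccc(S(=O)(=O)n2cc(-c3cc(C(F)(F)F)c(C#N)c(-c4cn(S(=O)(=O)c5ccc(C)cc5)c5cc(Br)ccc45)n3)c3ccc(Br)cc32)cc1` has not been measured; it differs from compound 2 by cyano in place of hydrogen on an aromatic carbon. Going by the values given here, no step between measured compounds is available to guide the direction, so in this assay a step of a number 0.9 percentage points higher from compound 2 to compound 3 (within the scatter) is expected, none beyond the scatter. Compound 3 is accordingly expected to give about 9%, within a range from 0% to 25%.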

Compound 3, a percentage reported as inhibition, at one concentration (the size of the read-out at that concentration, not a potency): 3.1%
The estimate for compound 3 lay 5.9 percentage points above the measured number; the measured number falls inside the stated range.
By their numbers in this assay, from the lowest: compounds 3, 2 and 1 (each within the scatter of the next).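

Cyano in place of hydrogen on this aromatic carbon, ortho to a trifluoromethyl group and two atoms from the ring nitrogen, brings in this assay a step of a number 5 percentage points lower from compound 2 to compound 3 (within the scatter) and so leaves the read-out level with that of the parent. This single step therefore gives no direction for the position at the one concentration tested. Nothing available here bears on the reason for this result. From the compounds shown here alone, whether an amine or a carboxylic acid on this carbon would move the number beyond the scatter remains open, and so does the effect of cyano on the core of compound 1.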